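Amide-linked series: ring swap on the propoxy chain

This account rests on a few compounds, and the source may have more. Where it says the series, first, only, none or still open, it means among the compounds named here.

Compound 1 `COc1cc2c(Nc3nc4ccc(C(=O)Nc5c(C)cccc5C)cc4s3)ncnc2cc1OCCCN1CCCC1` is the weaker of the two compounds measured in a functional assay on A549 cells (Homo sapiens) for cytotoxicity, read by WST assay, with a stated time of 72 h; on this read-out lower numbers stand for stronger inhibition and higher numbers for weaker inhibition: in this assay compound 1 gives 83800 nM, the highest number of the two. Compound 2 `COc1cc2c(Nc3nc4ccc(C(=O)Nc5c(C)cc(C)cc5C)cc4s3)ncnc2cc1OCCCN1CCCCC1C` gives 5800 nM in this assay; it differs from compound 1 in more than one place, so only the two values themselves are available for comparison, and they lie beyond the scatter of each other.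

Compound 3 `COc1cc2c(Nc3nc4ccc(C(=O)Nc5c(C)cccc5C)cc4s3)ncnc2cc1OCCCN1CCC(C)CC1` has not yet been measured. It differs from compound 1 by one change: 4-methylpiperidin-1-yl in place of pyrrolidin-1-yl on a saturated chain carbon, three bonds along the chain from an oxygen on an aromatic ring. Among the compounds with values here, no measured pair carries this exact change on its own, so the size of the step rests on judgement only. A step no larger than the scatter, or a modest move toward lower numbers, is expected; the step from compound 1 to compound 3 is estimated at a 2.1-fold lower number from compound 1 to compound 3 (0.32 log units; beyond the scatter). For compound 3 in this assay a value of 40000 nM is expected, within a range from 12000 nM to 120000 nM.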

Compound 3, half-maximal inhibitory concentration: 89700 nM
For compound 3 the middle estimate is 2.2-fold (0.35 log units) below the measured one, within the range that was stated.
By their numbers in this assay, from the lowest: compound 2; then compounds 1 and 3 (each within the scatter of the next).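

In this assay the step is a 1.1-fold higher number from compound 1 to compound 3 (0.03 log units; within the scatter) when 4-methylpiperidin-1-yl takes the place of pyrrolidin-1-yl on a saturated chain carbon, three bonds along the chain from an oxygen on an aromatic ring. Within the data shown here, this is the first change that can be read in one place, and on the core of compound 1 the swap of a five-membered for a six-membered non-aromatic ring, with the added methyl, leaves the two compounds indistinguishable on this read-out. No supporting measurement is available to account for this result.

Still open, going by these compounds, is whether a morpholin-4-yl or dimethylamino group at the end of the same chain would also stay within the scatter of compound 1. A longer chain carrying the pyrrolidin-1-yl ring is equally untested in the compounds shown here.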